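The source may report more compounds than this note shows. Statements on the series, on what has been measured and on what is new or still open speak of the compounds shown alone.

Measured so far in a functional assay on HT-29 cells (Homo sapiens) for cytotoxicity, read by MTT assay (a higher number here means a weaker inhibitor, a lower number a stronger inhibitor), with each compound's value:
- compound 1 `C=C1C(=O)[C@]23C[C@@]1(Cl)CC[C@H]2[C@@]12C=CC(=O)[C@](C)(C(=O)O1)[C@H]2[C@@H]3C(=O)OC` gives 2900 nM
- compound 2 `C=C1C(=O)[C@]23C[C@@]1(O)CC[C@H]2[C@@]12C=CC(=O)[C@](C)(C(=O)O1)[C@H]2[C@@H]3C(=O)OC` gives 65700 nM
- compound 3 `C=C1C(=O)[C@]23C[C@@]1(O)CC[C@H]2[C@@]12C=CC(=O)[C@](C)(C(=O)O1)[C@H]2[C@@H]3C(=O)OCc1ccccc1` gives 83300 nM

Compound 3 stands with compound 2 at the high end of these numbers, the two within the scatter of each other, while compound 1 lies far lower. The next compound is compound 4 `C=C1C(=O)[C@]23C[C@@]1(F)CC[C@H]2[C@@]12C=CC(=O)[C@](C)(C(=O)O1)[C@H]2[C@@H]3C(=O)OCc1ccccc1`, which carries fluoro in place of hydroxy on a saturated ring carbon. The closest evidence at that ring carbon is a 23-fold higher number from compound 1 to compound 2 (1.36 log units; beyond the scatter), a large step with hydroxy in place of chloro. Read in reverse, it points to a lower number when a halogen replaces hydroxy. The other step, a 1.3-fold higher number from compound 2 to compound 3 (0.10 log units; within the scatter), with phenyl in place of hydrogen on a saturated chain carbon bound to an oxygen next to a carbonyl group, gives no reason to expect the benzyl-bearing compound 3 to behave differently. Among the measured compounds shown here, no fluoro compound has been measured, so the direction carries over better than the size, and a smaller step than the one seen with chloro is the cautious expectation. In this assay the estimate is a 6.9-fold lower number from compound 3 to compound 4 (0.84 log units; beyond the scatter) and this expected step lies beyond the scatter. Compound 4 is estimated at 12000 nM with 3000 nM to 45000 nM as the expected range for it.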

Compound 4, half-maximal inhibitory concentration: 59100 nM
Beside the measured number, compound 4's estimate is 4.9-fold (0.69 log units) below it; the measured number lies above the stated range.
By their numbers in this assay, from the lowest: compound 1; then compounds 4, 2 and 3 (each within the scatter of the next).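

In this assay the exchange of hydroxy for fluoro on this saturated ring carbon gives a 1.4-fold lower number from compound 3 to compound 4 (0.15 log units; within the scatter), so on the benzyl ester this change leaves the number within the scatter. Among the compounds shown here, a halogen in place of hydroxy therefore does not carry a large step in every setting: the only large step at this ring carbon is the one involving chloro, a 23-fold higher number from compound 1 to compound 2 (1.36 log units; beyond the scatter), and it stands on the methyl ester, so the two steps differ both in the halogen and in the ester, and they cannot separate these two differences. No measurement at hand accounts for the contrast between the two steps.

Still open, going by these compounds, is whether chloro on the benzyl ester of compound 3 would give a large step, and whether fluoro on the methyl ester of compound 2 would stay within the scatter as it does here. Also open, on these data alone, is how bromo, an amine or a methoxy group on this ring carbon would read in this assay, and whether any of them would fall with chloro or with fluoro.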